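The source may hold more compounds than are shown below. What is called first, only, known or untested is meant among the compounds shown, and "the series" means these compounds.

Working notes on the series

Compound 1 `CC(=O)Nc1ccc(O)c(C(=O)/C=C/c2ccc(F)cc2)c1` and compound 2 `COc1ccc(-c2cc(=O)c3cc(NC(C)=O)ccc3o2)cc1` have both been measured in an ADME assay on MT4 cells (Homo sapiens) for cytotoxicity, read by MTT assay, with a stated time of 4 days; on this read-out lower numbers stand for higher toxicity in this test and higher numbers for lower toxicity in this test. In this assay compound 1 gives 41100 nM, and compound 2 gives 226000 nM. Compound 2 therefore stands at the highest of the two numbers recorded, with compound 1 as its nearest neighbour at a lower number, a gap that lies beyond the usual scatter of the measurement. Among the measured compounds shown here, no pair of measured compounds differs in a single place, so no isolated structural step has yet been read in this assay.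

Compound 3 `CC(=O)Nc1ccc2oc(-c3ccc(C(F)(F)F)cc3)cc(=O)c2c1` has not been measured. It differs from compound 2 in one place: trifluoromethyl in place of methoxy on an aromatic carbon, the new group sitting on an aromatic carbon of a six-membered aromatic ring of carbon only, para to a large group.

For the measured compounds named here, with no comparable step on record, the expectation rests on the value of compound 2 alone: the step from compound 2 to compound 3 is expected to be a 1.5-fold lower number from compound 2 to compound 3 (0.18 log units; within the scatter), that is, no change beyond the scatter, with a modest lean toward a lower number. On this basis compound 3 is estimated at 150000 nM, with a range from 50000 nM to 400000 nM.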

Compound 3, half-maximal cytotoxic concentration: 330000 nM
Estimate against measurement, compound 3: 2.2-fold (0.34 log units) below; the measured number falls inside the stated range.
By their numbers in this assay, from the lowest: compound 1; then compounds 2 and 3 (each within the scatter of the next).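

Among the compounds shown here, the step of a 1.5-fold higher number from compound 2 to compound 3 (0.16 log units; within the scatter) is the first single-place change that can be read in this assay, and it concerns an aromatic carbon of a six-membered aromatic ring of carbon only, para to a large group. For the compounds shown here, in this one pair the read-out does not separate trifluoromethyl from methoxy at that place, a reading the earlier compounds could not give, since no single-place pair stood among them. The data available give no measured property or other information that bears on this result, and so the step stands as an observation without an explanation.

As far as these compounds go, whether a different group at the same place, such as an amine or a carboxylic acid, would also stay within the scatter remains open, and one pair cannot show how far the tolerance seen here extends. Also open, from the compounds shown here alone, is whether the same exchange of methoxy for trifluoromethyl would give a similar result on the core of compound 1, which so far has no single-place partner.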